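From Nitro to Methoxy on a Scaffold at the Limit

The compounds below may be only part of what the source reports. "The series", "measured", "known", "first", "only" and "open" are said of these compounds alone.

Compound 2 `CC(C)n1ncc2c(C(=O)NCc3cn(-c4ccc([N+](=O)[O-])cc4)nn3)cccc21` carries a nitro group. In a functional assay on MGC-803 cells (Homo sapiens) for inhibition, read by MTT assay, with a stated time of 72 h (on this read-out higher numbers stand for weaker inhibition and lower numbers for stronger inhibition), compound 2 gives > 40000 nM, which is a limit of the assay rather than a number. Compound 1 `CC(C)n1ncc2c(C(=O)NCc3cn(-c4ccc(I)cc4)nn3)cccc21` carries iodo instead. In this assay compound 1 gives > 40000 nM, again a limit. The step that the two limits leave unreadable from compound 1 to compound 2 therefore cannot be read, since the limit of > 40000 nM in this assay, at which 2 of the 2 values shown sit, covers both values. Compound 3 `COc1ccc(-n2cc(CNC(=O)c3cccc4c3cnn4C(C)C)nn2)cc1` arises from compound 2 by methoxy in place of nitro on an aromatic carbon. Going by the values given here, no measured step has a readable size, so nothing shows that a change at this position moves the read-out, and the expectation is that compound 3 also sits at the limit. The step that the limit leaves unreadable from compound 2 to compound 3 is therefore expected to be about none beyond the scatter. Compound 3 is estimated at 45000 nM, within 15000 nM to 150000 nM, with a strong chance that only a limit is reported.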

Compound 3, half-maximal inhibitory concentration: > 40000 nM
Compound 3: a limit, no number; the forecaster's own chance of this, stated with the estimate: 80%; the middle value lies beyond the limit too.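

Compound 3 also ends at a limit rather than a number, so no step among compound 1, compound 2 and compound 3 can be read: the limit of > 40000 nM in this assay, at which 3 of the 3 values shown sit.

The compounds shown leave open whether any group at this place moves the read-out in this assay, and how far these three compounds differ from one another.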